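The source may hold more compounds than are shown below. What is called first, only, known or untested is meant among the compounds shown, and "the series" means these compounds.

Measured so far:
compound 1 `CCO[C@H]1CC=C2CCN(C)[C@H]2C1`, 300000 nM
compound 2 `CN1CCC2=CC[C@H](OCc3ccccc3)C[C@@H]21`, 300000 nM
compound 3 `O[C@H]1CC[C@H]2CCN[C@H]2C1`, > 300000 nM

In an assay on HEK293 cells for displacement of a labelled ligand from Neuronal acetylcholine receptor; alpha4/beta2 (Rattus norvegicus), with a stated time of 4 h (a lower number here means a stronger inhibitor, a higher number a weaker inhibitor), compound 1 gives 300000 nM and sits level with compound 2, which gives 300000 nM. For compound 3 the entry is a limit of the assay, > 300000 nM, and it is the one limit among the three, matching (the limit of > 300000 nM in this assay, at which 1 of the 3 values shown sits). Among the measured compounds shown here, the only measured step, no change at the digits printed from compound 1 to compound 2 (within the scatter), alters the group on the oxygen without moving the number. Compound 4 `CN1CCC2=CC[C@H](O)C[C@@H]21` differs from compound 1 by hydrogen in place of ethyl on an oxygen on a saturated carbon, again a change at that oxygen, so the measured step points to no movement beyond the scatter. Compound 4 is therefore expected near 300000 nM, with a range of 150000 nM to 600000 nM. The expected step is no change at the digits printed from compound 1 to compound 4 (within the scatter), and a limit rather than a number may well be reported.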

Compound 4, inhibition constant: 300000 nM
Estimate against measurement, compound 4: no gap at the digits printed; measured number inside the range.
By their numbers in this assay, from the lowest: compounds 1, 2 and 4 (each within the scatter of the next).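

In this assay, ethoxy to hydroxy on this oxygen gives no change at the digits printed from compound 1 to compound 4 (within the scatter). Removing the ethyl altogether therefore reads the same as the phenyl in place of methyl in compound 2, so the position shows no response to either a smaller or a larger group. That flat reading holds only at the weak end of the scale, close to where the assay reaches its limit: the limit of > 300000 nM in this assay, at which 1 of the 4 values shown sits.

Still open, going by these compounds, is whether an amine or a carboxylic acid in place of the hydroxy would register at all. Also open, on these data alone, is whether the same insensitivity would hold on a core with a much lower number.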